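A ring exchange from compound 2 to compound 3

The compounds below may be only part of what the source reports. "The series", "measured", "known", "first", "only" and "open" are said of these compounds alone.

Compound 1 `Cc1cc(C)cc(S(=O)(=O)c2c(C(=O)NC3CN(Cc4ccccc4C#N)C3)[nH]c3ccc(Cl)cc23)c1`: > 234000 nM
Compound 2 `Cc1cc(C)cc(S(=O)(=O)c2c(C(=O)NC3CN(Cc4ccccc4F)C3)[nH]c3ccc(Cl)cc23)c1`: > 238000 nM
Compound 3 `Cc1cc(C)cc(S(=O)(=O)c2c(C(=O)NC3CN(Cc4n[nH]c(=O)n4C)C3)[nH]c3ccc(Cl)cc23)c1`: not yet measured

In an ADME assay on MT4 cells (Homo sapiens) for cytotoxicity, read by MTT assay, with a stated time of 5 days (a lower number here means that less compound is tolerated, a higher number that more compound is tolerated), compound 2 gives > 238000 nM, which is a limit of the assay and not a number. Compound 1 gives > 234000 nM, which is also a limit. The structural change is a group of 7 heavy atoms (3 carbon, 3 nitrogen, 1 oxygen; one five-membered aromatic ring with 3 hetero atoms) in place of a group of 7 heavy atoms (6 carbon, 1 fluorine; one six-membered aromatic ring of carbon only), on a saturated chain carbon bound to an amine nitrogen in a ring. Among the measured compounds shown here, the only measured step, a step that the two limits leave unreadable from compound 1 to compound 2, bears on it only loosely, since it alters a different kind of group and shows no size. With no readable step to carry over, no change beyond the scatter is expected in this assay, and no direction can be given. For compound 3 the estimated value is 236000 nM, with an expected range from 120000 nM to 240000 nM. This estimate means an expected a number no higher from compound 2 to compound 3 (the limit leaves the size open). Most likely the assay will again report only a limit.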

Compound 3, half-maximal cytotoxic concentration: 25200 nM
The estimate for compound 3 lay 9.4-fold (0.97 log units) above the measured number; the measured number lies below the stated range.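

This position is not silent in this assay: the five-membered aromatic ring with 3 hetero atoms gives an at least 9.4-fold lower number from compound 2 to compound 3 (0.97 log units; beyond the scatter) and an at least 9.2-fold lower number from compound 1 to compound 3 (0.96 log units; beyond the scatter), so less compound is tolerated with it, whereas the step between the two earlier compounds cannot be read. Compound 2 stands at a limit of the assay and not a number, so the true size of its step stays open: the limit of > 238000 nM in this assay, at which 1 of the 3 values shown sits. Compound 1 likewise stands at a limit and not a number: the limit of > 234000 nM in this assay, at which 1 of the 3 values shown sits.

The ring atoms, the double bond outside aromatic rings, the hydrogen-bond donor and the acceptors all enter in one step, and the compounds shown do not separate them. As far as these compounds go, whether a simple amine or a carboxylic acid on the same saturated chain carbon would give a number or a limit in this assay also stays open.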